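Swapping methyl for fluoro on compound 2

This account rests on a few compounds, and the source may have more. Where it says the series, first, only, none or still open, it means among the compounds named here.

In a functional assay on PC-3 cells (Homo sapiens) for cytotoxicity, read by MTT assay, with a stated time of 72 h (on this read-out lower numbers stand for stronger inhibition and higher numbers for weaker inhibition), compound 1 (`Cc1ccc(S(=O)(=O)c2nc3ccccc3nc2Nc2ccccc2)cc1`) gives 1060 nM and compound 2 (`Cc1ccc(S(=O)(=O)c2nc3ccccc3nc2Nc2ccc(N)cc2)cc1`) gives 5000 nM as the higher of the two numbers, which makes compound 2 the weaker of this pair. Within the data shown here, the one measured step is a 4.7-fold higher number from compound 1 to compound 2 (0.67 log units; beyond the scatter) and comes from amino in place of hydrogen on an aromatic carbon.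

Compound 3 (`Nc1ccc(Nc2nc3ccccc3nc2S(=O)(=O)c2ccc(F)cc2)cc1`) differs from compound 2 by a single swap, counted as fluoro in place of methyl on an aromatic carbon and described in words as fluoro in place of methyl on an aromatic carbon, para to a large group. The measured step was modest, but it concerns the amino group and not this swap, so it bears on the new change only indirectly. Among the measured compounds shown here, no measured pair here touches methyl or fluoro, and nothing points in either direction. No step beyond the usual scatter is therefore expected in this assay for this swap. The estimate means a 1.3-fold lower number from compound 2 to compound 3 (0.10 log units; within the scatter) and remains only an expectation. Compound 3 is estimated at 4000 nM with an expected range of 1500 nM to 11000 nM on this read-out.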

Compound 3, half-maximal inhibitory concentration: 2050 nM
The estimate for compound 3 lay 2.0-fold (0.29 log units) above the measured number, and the stated range covers the measured number.
By their numbers in this assay, from the lowest: compounds 1 and 3 (each within the scatter of the next); then compound 2.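

In this assay the change from 4-methylphenyl to 4-fluorophenyl gives a 2.4-fold lower number from compound 2 to compound 3 (0.39 log units; beyond the scatter) and so moves the number beyond the usual scatter. Among these compounds, the earlier step concerned only the amino group, so this is the first reading at this position, on an aromatic carbon para to a large group, and it shows that the position responds to the choice of substituent. The swap exchanges one heavy atom for one heavy atom, with no hydrogen-bond donor or acceptor counted on either side, yet even that is enough for a modest step, although nothing at hand explains why the number moves this way.

On these data alone, all of this rests on a single pair, so it remains open whether the same swap would give a similar step on compound 1, which lacks the amino group. As far as these compounds go, it also remains open how this position would respond to other groups, such as chloro, methoxy or a nitrile, and whether any of them would take the number lower than fluoro does.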